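Compound 3 to compound 4: isobutyl to tert-butyl

The source may hold more compounds than are shown below. What is called first, only, known or untested is meant among the compounds shown, and "the series" means these compounds.

In an ADME assay on Jurkat cells (Homo sapiens) for cytotoxicity, read by MTT assay, with a stated time of 72 h (a higher number here means a weaker inhibitor, a lower number a stronger inhibitor), compound 1 (`O=C(O)c1cnc(Oc2ccc3c(c2)B(O)OC3)cn1`) gives > 100000 nM as a limit of the assay, not a number. Compound 2 (`CC(C)OC(=O)c1cnc(Oc2ccc3c(c2)B(O)OC3)cn1`) gives > 100000 nM as a limit too. Going by the values given here, compound 3 (`CC(C)COC(=O)c1cnc(Oc2ccc3c(c2)B(O)OC3)cn1`) reads 17600 nM and is the only compound so far with an actual number.

The move to compound 4 (`CC(C)(C)OC(=O)c1cnc(Oc2ccc3c(c2)B(O)OC3)cn1`) puts tert-butyl in place of isobutyl on an oxygen next to a carbonyl group. The nearest measured change on that oxygen (an at least 5.6-fold lower number from compound 2 to compound 3 (0.75 log units; beyond the scatter)) is matched in size by the change from hydrogen (an at least 5.6-fold lower number from compound 1 to compound 3 (0.75 log units; beyond the scatter)), while the third step (a step that the two limits leave unreadable from compound 1 to compound 2) gives no size. Both readable steps are bounded by the limit of > 100000 nM in this assay, at which 2 of the 3 values shown sit, and so give only minimum sizes. Among the compounds with values here, no measured compound carries tert-butyl.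

A step of limited size to a higher number is expected in this assay because an at least 5.6-fold lower number from compound 2 to compound 3 (0.75 log units; beyond the scatter) shows that a swap of chains on this oxygen can move the reading beyond the scatter, and a result at the limit remains possible. The estimated step (a 2.3-fold higher number from compound 3 to compound 4 (0.36 log units; beyond the scatter)) is small. The estimated value for compound 4 is 40000 nM within an expected range from 12000 nM to 95000 nM in this series.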

Compound 4, half-maximal inhibitory concentration: > 100000 nM
Compound 4 ended at the assay's limit; the forecaster's own chance of this, stated with the estimate: 30%; middle value at least 2.5-fold (0.39 log units) from the limit.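

On an oxygen next to a carbonyl group, the two chains have the same atoms, joined differently, yet in this assay tert-butyl in place of isobutyl gives an at least 5.6-fold higher number from compound 3 to compound 4 (0.75 log units; beyond the scatter), so atom content alone does not set the reading at this position. Among the esters shown, only the isobutyl ester compound 3 gives an actual number, while the branched isopropyl ester compound 2 and the tert-butyl ester compound 4 both stay at the limit, as does the free acid compound 1. The steps among compound 1, compound 2 and compound 4 cannot be read, and any step that touches the limit gives only a minimum size: the limit of > 100000 nM in this assay, at which 3 of the 4 values shown sit.

The compounds shown leave open whether a longer unbranched chain, such as n-butyl or n-hexyl, would lower the number beyond that of compound 3. They also leave open how an amide in place of the ester would read.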